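Replacing 3-hydroxyphenyl with 4-(trifluoromethyl)phenyl: working notes

This account rests on a few compounds, and the source may have more. Where it says the series, first, only, none or still open, it means among the compounds named here.

In a functional assay on L1210 cells (Mus musculus) for inhibition, read by MTT assay, with a stated time of 72 h (a higher number here means a weaker inhibitor, a lower number a stronger inhibitor), compound 1 (`COc1cc(NC(C)CCCNC(=O)NNC(=O)Nc2ccc(Cl)cc2)c2ncccc2c1`) gives 58000 nM and compound 2 (`COc1cc(NC(C)CCCNC(=O)Nc2cccc(O)c2)c2ncccc2c1`) gives 25000 nM, the lower of the two numbers, which makes compound 2 the stronger inhibitor of this pair. Next is compound 3 (`COc1cc(NC(C)CCCNC(=O)Nc2ccc(C(F)(F)F)cc2)c2ncccc2c1`), with 4-(trifluoromethyl)phenyl in place of 3-hydroxyphenyl on an amide-type nitrogen. Within the data shown here, only one measured step bears on this change, and it falls at the same place: a 2.3-fold lower number from compound 1 to compound 2 (0.37 log units; beyond the scatter), modest but beyond the scatter. Neither measured compound carries the entering group, so that single step gives only a weak guide to size and none to direction. A modest move towards a lower number is expected, although no change beyond the scatter remains possible. The expected change is a 1.7-fold lower number from compound 2 to compound 3 (0.22 log units; within the scatter). For compound 3 the estimated value is 15000 nM, with an expected range of 5000 nM to 45000 nM.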

Compound 3, half-maximal inhibitory concentration: 7400 nM
Estimate against measurement, compound 3: 2.0-fold (0.31 log units) above; the measured number falls inside the stated range.
By their numbers in this assay, from the lowest: compound 3; then compound 2; then compound 1.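

At this amide-type nitrogen, 4-(trifluoromethyl)phenyl gives a 3.4-fold lower number from compound 2 to compound 3 (0.53 log units; beyond the scatter) in this assay, showing that exchanging one substituted phenyl for another at this place can move the number beyond the scatter, with a step larger than the first one seen here. Against the ((4-chlorophenyl)carbamoyl)amino group the same entering group gives a 7.8-fold lower number from compound 1 to compound 3 (0.89 log units; beyond the scatter), which makes compound 3 the strongest inhibitor of the three, and it carries no hydrogen-bond donor or acceptor in this group, so neither is required in the group at this place for the lower number. No measurement shown here accounts for the gain.

The 3-hydroxyphenyl and 4-(trifluoromethyl)phenyl groups differ both in the substituent and in where it stands on the phenyl ring, so the two contributions cannot be separated. Going by these compounds, how a nitrile, an amine or a carboxylic acid on that phenyl ring would compare also remains open.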